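The source may hold more compounds than are shown below. What is called first, only, known or untested is meant among the compounds shown, and "the series" means these compounds.

Working notes on the series in a functional assay on the whole organism for antagonist activity, with Mus musculus as the target; a higher number here means that more compound is needed for the effect, a lower number that less compound is needed.

Compound 1 `COC(=O)N(C)C(C)C#CCn1ccnc1` gives in this assay a limit of the assay, > 100 mg/kg, and not a number. Compound 2 `COC(=O)N(C)C(C)C#CCN(C)C` gives likewise only a limit, > 100 mg/kg. The change between them is dimethylamino in place of 1H-imidazol-1-yl on a saturated chain carbon bound to a triple-bonded carbon; the step that the two limits leave unreadable from compound 1 to compound 2 cannot be read, since both ends are limits. Compound 3 `Cn1ccn(CC#CCn2ccnc2)c1=O` also sits at a limit in this assay, > 100 mg/kg. The difference between the core of compound 3 and that of compound 1 is not broken down here.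

Compound 4 `CN(C)CC#CCn1ccn(C)c1=O` is not yet measured. From compound 3 to compound 4 the change is dimethylamino in place of 1H-imidazol-1-yl on a saturated chain carbon bound to a triple-bonded carbon, the same kind of change as from compound 1 to compound 2. Because (the limit of > 100 mg/kg in this assay, at which 3 of the 3 values shown sit), no readable size for this change exists, and the step that the limit leaves unreadable from compound 3 to compound 4 is expected to stay unreadable as well. Compound 4 is expected to give about 150 mg/kg in this assay, most likely again only a limit, within 50 mg/kg to 600 mg/kg.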

Compound 4, dose for half-maximal effect: > 100 mg/kg
Compound 4: a limit, no number (the forecaster's own chance of this, stated with the estimate: 80%); the middle value does not contradict the limit.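

No step can be read from compound 3 to compound 4 in this assay, since both ends are limits and not numbers: the limit of > 100 mg/kg in this assay, at which 4 of the 4 values shown sit.

The compounds shown leave open how large the change from 1H-imidazol-1-yl to dimethylamino is, and what dose any of them needs for half-maximal effect.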